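The compounds below may be only part of what the source reports. "The series", "measured", "known", "first", "only" and "open" are said of these compounds alone.

The measured compounds are:

Compound 1: `COc1ccccc1NC(=O)N[C@@H](C)c1ccccc1`, 95%
Compound 2: `CC(=O)c1ccccc1NC(=O)N[C@@H](C)c1ccccc1`, 96%

In an ADME assay on the whole organism with Oryza sativa as the target, tested at 10 uM (a lower number here means a stronger effect, a higher number a weaker effect of the compound at the concentration tested), compound 2 gives 96%. Of the two numbers shown it is the higher one, but only by a margin that means nothing, since the step of a number 1 percentage points higher from compound 1 to compound 2 (within the scatter) lies within the scatter. The companion value comes from compound 1, which gives 95% in this assay.

Compound 3 is `C[C@H](NC(=O)Nc1ccccc1Cl)c1ccccc1`. It differs from compound 2 as follows: chloro in place of acetyl on an aromatic carbon. Among the compounds with values here, the one measured step, a number 1 percentage points higher from compound 1 to compound 2 (within the scatter), also exchanged a group on an aromatic carbon of the same ring, and it left the read-out essentially unchanged. Within the data shown here, that step is the only guide here, and it does not involve chloro, so the expectation for compound 3 rests on a single comparison. On that basis the step from compound 2 to compound 3 is expected to be small, a number 4 percentage points lower from compound 2 to compound 3 (within the scatter), with no change beyond the scatter anticipated. Compound 3 is therefore estimated at 92% in this assay, within a range from 75% to 100%.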

Compound 3, a percentage reported as activity, at one concentration (the size of the read-out at that concentration, not a potency): 106%
Compound 3: middle estimate off by 14 percentage points, on the low side, and the stated range ends below it.
By their numbers in this assay, from the lowest: compounds 1, 2 and 3 (each within the scatter of the next, the first and the last beyond it).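

Within the data shown here, on this aromatic carbon, ortho to a large group, the read-out does respond to the group carried: a number 11 percentage points higher from compound 1 to compound 3 (beyond the scatter) is a modest change and the first step here to pass the scatter, while a number 10 percentage points higher from compound 2 to compound 3 (within the scatter) stays inside it. In this assay chloro is thus separated from methoxy but not from acetyl, and taking away the double bond and the hydrogen-bond acceptor of acetyl gives no change beyond the scatter. Nothing available explains why chloro and methoxy part in this way.

The compounds shown leave open whether the modest step belongs to chloro alone or would also appear with fluoro, bromo or methyl on the same carbon. They also leave open whether an amine or a carboxylic acid at this place would bring the number down, which would mean a stronger effect, since every step shown so far runs upward or stays within the scatter.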